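The source may report more compounds than this note shows. Statements on the series, on what has been measured and on what is new or still open speak of the compounds shown alone.

Values so far in a functional assay on MCF7 cells (Homo sapiens) for antiproliferative activity, read by MTT assay, with a stated time of 72 h; on this read-out higher numbers stand for weaker inhibition and lower numbers for stronger inhibition:

Compound 1 `CCOc1ccc(-c2ncnn2-c2cc(OC)c(OC)c(OC)c2)cc1Cl` gives 17 nM
Compound 2 `COc1cc(-n2ncnc2-c2ccc(OC(F)(F)F)cc2)cc(OC)c1OC` gives > 10000 nM
Compound 3 `COc1cc(-c2ncnn2-c2ccc(Cl)c(Cl)c2)cc(OC)c1OC` gives > 10000 nM

As far as these compounds go, the reading for compound 2 is a limit and not a number, so it sits at the limit of > 10000 nM in this assay, at which 2 of the 3 values shown sit, and its true position is unknown. The reading for compound 3 is also a limit. Compound 1 gives 17 nM in this assay, which shows that strong inhibition is possible in this small set.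

Compound 4 `COc1cc(-n2ncnc2-c2ccc(OC(C)C)cc2)cc(OC)c1OC` differs from compound 2 in one place: isopropyl in place of trifluoromethyl on an oxygen on an aromatic ring, trifluoromethoxy to isopropoxy. For the measured compounds named here, no measured pair isolates this change, so any move towards stronger inhibition is expected to be modest and uncertain, and another limit reading remains quite possible. The expected change is an at least 3.3-fold lower number from compound 2 to compound 4 (0.52 log units; beyond the scatter) as an estimate. For compound 4 the estimated value is 3000 nM, with an expected range of 300 nM to 10000 nM.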

Compound 4, half-maximal inhibitory concentration: 610 nM
Beside the measured number, compound 4's estimate is 4.9-fold (0.69 log units) above it, and the stated range covers the measured number.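

On an oxygen on an aromatic ring, isopropyl in place of trifluoromethyl moves the compound from no measurable number to a real one: in this assay the change gives an at least 16-fold lower number from compound 2 to compound 4 (1.21 log units; beyond the scatter) on an otherwise unchanged structure. For this pair, then, the group on this oxygen decides whether a number can be read at all. As far as these compounds go, the true size of the step stays unknown, since compound 2 is only a limit: the limit of > 10000 nM in this assay, at which 2 of the 4 values shown sit.

From the compounds shown here alone, how a longer chain or an amine on this oxygen would read remains open. So does whether this change would act the same way on a different core.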